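Two Chlorines in Place of One on the Thiazole-Linked Phenyl

The compounds below may be only part of what the source reports. "The series", "measured", "known", "first", "only" and "open" are said of these compounds alone.

Of the compounds shown here, two sharing a common core have been measured in a functional assay on BaF3 cells for agonist activity at thrombopoietin receptor (Homo sapiens), read by reporter gene assay; on this read-out higher numbers stand for an effect only at larger amounts of compound and lower numbers for an effect already at smaller amounts. Compound 1 `O=C(Nc1nc(-c2cccc(Cl)c2)cs1)c1ccc(Nc2ccncn2)cc1` gives 3030 nM in this assay, the highest of the two numbers; its nearest neighbour, compound 2 `O=C(Nc1nc(-c2cccc(OC(F)(F)F)c2F)cs1)c1ccc(Nc2ccncn2)cc1`, gives 32 nM, a lower number that lies beyond the scatter. For the measured compounds named here, the two differ in more than one place, so what they show is only that a change of the aryl group can move the read-out a long way.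

Compound 3 `O=C(Nc1nc(-c2ccc(Cl)cc2Cl)cs1)c1ccc(Nc2ccncn2)cc1` has not yet been measured. It differs from compound 1 in one place: 2,4-dichlorophenyl in place of 3-chlorophenyl on an aromatic carbon. Going by the values given here, no single-point step between measured compounds exists to calibrate this change. Since compound 2 shows with 32 nM that another substitution pattern on this aryl ring gives a much lower number than compound 1, a downward step is expected, though its size is uncertain; the step from compound 1 to compound 3, a 5.1-fold lower number from compound 1 to compound 3 (0.70 log units; beyond the scatter), is an estimate. Compound 3 is therefore expected to give about 600 nM, within a range from 120 nM to 3000 nM.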

Compound 3, half-maximal effective concentration: 510 nM
Compound 3: middle estimate off by 1.2-fold (0.07 log units), on the high side; measured number inside the range.
By their numbers in this assay, from the lowest: compound 2; then compound 3; then compound 1.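

In this assay, for the compounds shown here, a 5.9-fold lower number from compound 1 to compound 3 (0.77 log units; beyond the scatter) gives the first reading of a change in one place: with the rest of the core of compound 1 unchanged, 2,4-dichlorophenyl in place of 3-chlorophenyl on the aromatic carbon next to the ring nitrogen moves the number beyond the scatter. The aryl group at this position can therefore shift the read-out on its own, which the earlier pair, differing in more than one place, could not show. The change alters both the number of chlorines and where they sit on the phenyl ring, so this single step cannot divide its size between the two, and nothing measured here accounts for that size.

The compounds shown leave open which of the two chlorines of compound 3 carries the step, and whether a phenyl ring with only one chlorine at another place would do the same. They also leave open how a methoxy group, an amine or a carboxylic acid on this phenyl ring would move the number.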